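Replacing a chloro group in a high-exposure compound

The compounds below may be only part of what the source reports. "The series", "measured", "known", "first", "only" and "open" are said of these compounds alone.

Measured in an in vivo ADME assay on the whole organism (plasma) for pharmacokinetics, with Rattus norvegicus as the target, at a dose of 50 mg/kg by the oral route; on this read-out higher numbers stand for higher exposure at the dose given and lower numbers for lower exposure:
- compound 1 `Cc1cc(C)c(N(C)C)c(C)c1NC(=O)c1sccc1S(=O)(=O)Nc1onc(C)c1Cl`: 6620 nM
- compound 2 `Cc1cc(C)c(NC(=O)c2sccc2S(=O)(=O)Nc2onc(C)c2Cl)c(C)c1O`: 106000 nM
- compound 3 `Cc1cc(C)c(NC(=O)c2sccc2S(=O)(=O)Nc2onc(C)c2Cl)c(Cl)c1`: 103000 nM

Compound 3 lies within the scatter of compound 2 and well beyond it from compound 1. Compound 4 `CO/N=C(\C)c1cc(C)cc(C)c1NC(=O)c1sccc1S(=O)(=O)Nc1onc(C)c1Cl` departs from compound 3 as follows: a group of 5 heavy atoms (3 carbon, 1 nitrogen, 1 oxygen; no ring) in place of one chlorine atom, on an aromatic carbon. Within the data shown here, the only measured step, a 16-fold higher number from compound 1 to compound 2 (1.20 log units; beyond the scatter), is large, but it is a different exchange, so it shows only that one substituent can move this assay strongly. Among the measured compounds shown here, no measured step replaces chloro. A moderate fall is expected, since compound 3, at 103000 nM, already stands near the top of the values seen. The expected change is a 2.6-fold lower number from compound 3 to compound 4 (0.41 log units; beyond the scatter). For compound 4 the estimate is 40000 nM, with an expected range of 10000 nM to 120000 nM.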

Compound 4, maximal plasma concentration: 27800 nM
For compound 4 the middle estimate is 1.4-fold (0.16 log units) above the measured one, and the stated range covers the measured number.
By their numbers in this assay, from the lowest: compound 1; then compound 4; then compounds 3 and 2 (each within the scatter of the next).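

In this assay, among these compounds, the exchange of chloro for the group of 5 heavy atoms gives a 3.7-fold lower number from compound 3 to compound 4 (0.57 log units; beyond the scatter) on this aromatic carbon, the first measured change at this position. The position therefore accepts a much larger group, one with 2 hydrogen-bond acceptors, at a modest cost, and compound 4 still gives 27800 nM in the same assay. Nothing available explains the fall. On these data alone, whether a methoxy group or a nitrile on this carbon would stay closer to compound 3 remains open.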